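The source may hold more compounds than are shown below. What is called first, only, known or untested is meant among the compounds shown, and "the series" means these compounds.

Working notes on the shared core, a furan-linked hydroxyphenyl amide carrying a methylated nitrogen.

Within the data shown here, compound 1 `Cc1c(F)cccc1N(C)C(=O)c1ccc(-c2ccc(O)cc2)o1` is the only member of the set with a number rather than a limit: in an assay on cytosol from placenta for inhibition of 17-beta-hydroxysteroid dehydrogenase type 2 (Homo sapiens), read by HPLC, using microsomes, with a stated time of 10 min, in the presence of a further agent that is not named here (on this read-out higher numbers stand for weaker inhibition and lower numbers for stronger inhibition), compound 1 gives 3900 nM. Compound 2 `Cc1cccnc1N(C)C(=O)c1ccc(-c2ccc(O)cc2)o1` sits at a limit of the assay, with compound 2 reading > 10000 nM in this assay. Compound 3 `Cc1ccncc1N(C)C(=O)c1ccc(-c2ccc(O)cc2)o1` likewise sits at a limit, compound 3 reading > 20000 nM in this assay. The two pyridyl amides thus stand at the weak end of what is shown; the step of an at least 2.5-fold higher number from compound 1 to compound 2 (0.40 log units; beyond the scatter) and the step of an at least 5.1-fold higher number from compound 1 to compound 3 (0.70 log units; beyond the scatter) both run from a number to a limit, while a step that the two limits leave unreadable from compound 2 to compound 3 cannot be sized, because both ends are limits the limit of > 10000 nM in this assay, at which 1 of the 3 values shown sits (the limit of > 20000 nM in this assay, at which 1 of the 3 values shown sits).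

Compound 4 `Cc1ncccc1N(C)C(=O)c1ccc(-c2ccc(O)cc2)o1` differs from compound 3 in one place: 2-methylpyridin-3-yl in place of 4-methylpyridin-3-yl on an amide-type nitrogen. Among the measured compounds shown here, no measured pair moves one methyl across a pyridyl ring in this way, so the only bearing comes from the three pyridyl-against-phenyl and pyridyl-against-pyridyl comparisons above, all of which end at limits in this assay. Compound 4 is therefore expected to stay weak, with the step of an at least 1.3-fold lower number from compound 3 to compound 4 (0.12 log units; that floor lies within the scatter) estimated as not readable beyond the scatter. Compound 4 is estimated at 15000 nM, within 4000 nM to 50000 nM, in this assay, most likely again as a limit.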

Compound 4, half-maximal inhibitory concentration: > 30000 nM
Compound 4: a limit, no number; the forecaster's own chance of this, stated with the estimate: 65%; middle value at least 2.0-fold (0.30 log units) from the limit.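

Compound 4 also stops at a limit of the assay, not at a number: the limit of > 30000 nM in this assay, at which 1 of the 4 values shown sits. With it, all three methylpyridyl groups on the amide-type nitrogen, in compound 2, compound 3 and compound 4, stay at limits in this assay, so 2-methylpyridin-3-yl gives no more readable inhibition than 4-methylpyridin-3-yl or 3-methylpyridin-2-yl, and no compound among these three goes against that pattern; the steps among these three cannot be read, as limits stand at both ends. Against the only compound with a number, the replacement of 3-fluoro-2-methylphenyl gives an at least 7.6-fold higher number from compound 1 to compound 4 (0.88 log units; beyond the scatter), and this is a floor set by a limit, not a measured size, so it cannot rank 2-methylpyridin-3-yl against the other two pyridyl groups.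

As far as these compounds go, the order of the three methylpyridyl groups stays open, and so does the true distance of any of them from compound 1, since none has a number. Also open, from the compounds shown here alone, is how a plain 2-methylphenyl group on the same nitrogen would read, which would separate the part played by the fluoro group from that of the ring nitrogen in the step away from compound 1.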